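The source may hold more compounds than are shown below. What is called first, only, known or untested is meant among the compounds shown, and "the series" means these compounds.

Measured so far in an ADME assay on HaCaT cells (Homo sapiens) for cytotoxicity, read by MTT assay, with a stated time of 72 h; a higher number here means a weaker inhibitor, a lower number a stronger inhibitor:
- compound 1, `Cc1cc(S(=O)(=O)/N=C(\N)n2nccc2-c2ccccc2)c(SCc2ccccc2)cc1Cl`, 18000 nM
- compound 2, `Cc1cc(S(=O)(=O)/N=C(\N)n2nccc2-c2ccccc2)c(SCc2ccc(C(F)(F)F)cc2)cc1Cl`, 19000 nM
- compound 3, `Cc1cc(S(=O)(=O)/N=C(\N)n2nccc2-c2ccccc2)c(SCc2ccccc2C(F)(F)F)cc1Cl`, 20000 nM

Compound 3 sits alongside the other two in this assay: a 1.1-fold higher number from compound 1 to compound 3 (0.05 log units; within the scatter) and a 1.1-fold higher number from compound 2 to compound 3 (0.02 log units; within the scatter) are both within the scatter, as is a 1.1-fold higher number from compound 1 to compound 2 (0.02 log units; within the scatter). The series therefore shows no movement at all across the three benzyl variants.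

Compound 4, `Cc1cc(S(=O)(=O)/N=C(\N)n2nccc2-c2ccccc2)c(SCc2ccc(Cl)cc2)cc1Cl`, has not been measured. Its change from compound 3 is 4-chlorophenyl in place of 2-(trifluoromethyl)phenyl on a saturated chain carbon bound to a sulfur. The bearing steps are the three above, all changes on the same benzyl group, and none left the scatter. No step beyond the scatter is therefore expected for this change either; the expected step is a 1.1-fold lower number from compound 3 to compound 4 (0.02 log units; within the scatter). Compound 4 is estimated at 19000 nM in this assay, with a range of 10000 nM to 38000 nM.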

Compound 4, half-maximal inhibitory concentration: 12000 nM
For compound 4 the middle estimate is 1.6-fold (0.20 log units) above the measured one, within the range that was stated.
By their numbers in this assay, from the lowest: compounds 4, 1, 2 and 3 (each within the scatter of the next).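

In this assay, 4-chlorophenyl on the saturated chain carbon bound to a sulfur stays within the scatter of all three earlier variants (a 1.7-fold lower number from compound 3 to compound 4 (0.22 log units; within the scatter); a 1.6-fold lower number from compound 2 to compound 4 (0.20 log units; within the scatter); a 1.5-fold lower number from compound 1 to compound 4 (0.18 log units; within the scatter)). These are the largest steps yet seen at this position, but chloro, like trifluoromethyl, still produces no step beyond the scatter. No supporting measurement bears on these small differences. Still open, as far as these compounds go, is whether an amine or a carboxylic acid on the aromatic ring, or a longer chain in place of the benzyl group, would move the number beyond the scatter.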